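The source may hold more compounds than are shown below. What is called first, only, known or untested is meant among the compounds shown, and "the series" means these compounds.

Compound 1 `O=C(N/N=C/c1ccccc1)c1cnccn1` gives 100%.
Compound 2 `O=C(N/N=C/c1cccc(Cl)c1)c1cnccn1` gives 100%.
Compound 3 `O=C(N/N=C/c1ccc(Cl)cc1)c1cnccn1` gives 83%.

These values all come from an ADME assay on J774 cells (Mus musculus) for cytotoxicity, read by MTT assay, with a stated time of 48 h, tested at 50 ug/mL; on this read-out higher numbers stand for a weaker effect at the one concentration tested and lower numbers for a stronger effect. On these numbers compound 1 stands level with compound 2 at the digits printed, and together the two are the highest of the three; the nearest neighbour of compound 1 is compound 2, with no change at the digits printed from compound 1 to compound 2 (within the scatter), and the furthest is compound 3, with a number 17 percentage points lower from compound 1 to compound 3 (beyond the scatter).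

Compound 4 `O=C(N/N=C/c1ccccc1F)c1cnccn1` differs from compound 1 by fluoro in place of hydrogen on an aromatic carbon. Neither measured step places a fluorine: both put chloro in place of hydrogen on an aromatic carbon, at different carbons of the ring, and their outcomes split, one staying within the scatter and the other giving a modest drop. Among the measured compounds shown here, a fluorine on this ring has no measured precedent here, so the two chloro steps are the only guide. The step in this assay from compound 1 to compound 4 is therefore expected to be small, most likely within the scatter, with a modest drop as the less likely alternative. Compound 4 is estimated at 95%, in the range 78% to 100%. That expectation amounts to a number 5 percentage points lower from compound 1 to compound 4 (within the scatter).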

Compound 4, a percentage reported as activity, at one concentration (the size of the read-out at that concentration, not a potency): 100%
Estimate against measurement, compound 4: 5 percentage points below; low and high end bracket the measured number.
By their numbers in this assay, from the lowest: compound 3; then compounds 1, 2 and 4 (each within the scatter of the next).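

In this assay, a fluoro group on the aromatic carbon ortho to a large group leaves the read-out unmoved, with no change at the digits printed from compound 1 to compound 4 (within the scatter) as the step. Among the compounds shown here, the earlier compounds carried only chloro, at other carbons of the ring, and split between no change at the digits printed from compound 1 to compound 2 (within the scatter) and a number 17 percentage points lower from compound 1 to compound 3 (beyond the scatter) as their steps; this result adds a different halogen at a different carbon and shows that, of the three single changes made to compound 1, only the one to compound 3 moves the number beyond the scatter. Nothing measured here says why this position and this change leave the read-out flat.

On these data alone, it remains open whether a bigger group on this same carbon, such as chloro, methoxy or an amine, would also leave the number level, or whether the flat result holds only for something as small as a single fluorine. As far as these compounds go, it also remains open whether fluoro on the carbon that carries chloro in compound 3 would give a drop like the one seen there, which would separate the effect of the place from that of the group.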